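A few compounds are considered here, and "the series" means these few. Any claim that something is new, unique, unknown or untested is made for them only; others in the source may bear on it.

Measured so far in an assay on HEK293 cells for negative allosteric modulation of metabotropic glutamate receptor 5 (Homo sapiens), read by FLIPR; on this read-out higher numbers stand for weaker inhibition and lower numbers for stronger inhibition:
- compound 1 `O=C(c1cccc(F)c1)N1CC(c2nc(-c3cccc(Cl)c3)no2)C1`: 780 nM
- compound 2 `COC1CCCN(C(=O)N2CC(c3nc(-c4cccc(Cl)c4)no3)C2)C1`: 1830 nM

Compound 2 stands at the highest of the two numbers, the one standing for the weaker inhibition; its nearest neighbour is compound 1, which differs from it only on the carbonyl carbon and gives a lower number. For the measured compounds named here, the single step available, a 2.3-fold higher number from compound 1 to compound 2 (0.37 log units; beyond the scatter), replaced 3-fluorophenyl with 3-methoxypiperidin-1-yl, and it was modest but beyond the scatter.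

Compound 3 `O=C(c1ccc(F)cc1)N1CC(c2nc(-c3cccc(Cl)c3)no2)C1` has not yet been measured. It differs from compound 2 as follows: 4-fluorophenyl in place of 3-methoxypiperidin-1-yl on a carbonyl carbon. This change undoes the aryl-to-piperidinyl exchange seen between compound 1 and compound 2, while the fluorine now sits on a 4-fluorophenyl rather than on a 3-fluorophenyl. Going by the values given here, the only step that bears on it is a 2.3-fold higher number from compound 1 to compound 2 (0.37 log units; beyond the scatter), so the reverse direction is expected in this assay: a return towards the number of compound 1, with the shift of the fluorine adding uncertainty but no measured step of its own. The step of a 2.2-fold lower number from compound 2 to compound 3 (0.33 log units; beyond the scatter) is therefore the expected outcome. Compound 3 is accordingly estimated at 850 nM, within a range of 300 nM to 2500 nM.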

Compound 3, half-maximal inhibitory concentration: 4000 nM
For compound 3 the middle estimate is 4.7-fold (0.67 log units) below the measured one; measured number outside the range, above it.
By their numbers in this assay, from the lowest: compound 1; then compound 2; then compound 3.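

In this assay, moving the fluorine from 3-fluorophenyl to 4-fluorophenyl on the carbonyl carbon gives a 5.1-fold higher number from compound 1 to compound 3 (0.71 log units; beyond the scatter), so this position responds to where the fluorine sits on the aromatic ring and not only to whether an aromatic ring or a saturated ring stands there. An aromatic ring on this carbon therefore does not by itself bring the lower number: exchanging 3-methoxypiperidin-1-yl for 4-fluorophenyl gives a 2.2-fold higher number from compound 2 to compound 3 (0.34 log units; beyond the scatter), which places compound 2, with its saturated ring, in the middle of the order and the two fluorophenyl compounds at either end. Nothing among the data shown offers an explanation for this sensitivity to the place of the fluorine.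

The compounds shown leave open how a plain phenyl group without fluorine would compare with the two fluorophenyl groups, and so whether the fluorine in compound 1 helps or the fluorine in compound 3 hinders. They also leave open what a plain piperidin-1-yl group without the methoxy would give, and whether a pyridine ring on the carbonyl carbon would follow the aromatic compounds at all.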